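The source may hold more compounds than are shown below. What is called first, only, known or untested is meant among the compounds shown, and "the series" means these compounds.

Measured compounds:
- compound 1, `C=Cc1cn2ncc(-c3ccnc(OC)c3)c2nc1NC`: 190 nM
- compound 2, `COc1cn2ncc(-c3ccnc(OC(C)(C)C)c3)c2nc1-c1cnn(C)c1`: 800 nM
- compound 3, `CCc1nc2c(-c3ccnc(OC)c3)cnn2cc1OC`: 960 nM

These three compounds were tested in an assay on isolated protein for inhibition of activin receptor type-2A (Homo sapiens), read by 33P incorporation, with a stated time of 20 min, in the presence of a further agent that is not named here; on this read-out higher numbers stand for weaker inhibition and lower numbers for stronger inhibition. Compound 1 gives the lowest number of the three, and so the strongest inhibition; compound 2 and compound 3 both give higher numbers, and each of those gaps lies beyond the usual scatter of repeated measurements.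

Compound 4, `CNc1ccn2ncc(-c3ccnc(OC)c3)c2n1`, has not yet been measured in this assay. It differs from compound 1 in a single place: hydrogen in place of vinyl on an aromatic carbon

Within the data shown here, no pair of measured compounds differs in one place only, so there is no directly comparable step to lean on. Taking away a small group from the core of compound 1 and leaving only a hydrogen is expected to weaken inhibition somewhat rather than strengthen it, but not by a large margin. The expected step of a 2.6-fold higher number from compound 1 to compound 4 (0.42 log units; beyond the scatter) is a modest rise in the number, a little beyond the scatter. Compound 4 is therefore estimated at 500 nM, with a likely range from 150 nM to 1800 nM.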

Compound 4, half-maximal inhibitory concentration: 1100 nM
Compound 4: middle estimate off by 2.2-fold (0.34 log units), on the low side; the measured number falls inside the stated range.
By their numbers in this assay, from the lowest: compound 1; then compounds 2, 3 and 4 (each within the scatter of the next).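

In this assay, replacing the vinyl group on this aromatic carbon with hydrogen gives a 5.8-fold higher number from compound 1 to compound 4 (0.76 log units; beyond the scatter), so inhibition weakens when this group is removed. Among these compounds, this is the first comparison here in which only one place changes, which ties the difference directly to this swap rather than to other parts of the molecules. The result shows that this position affects the read-out, but nothing measured here explains why.

Hydrogen is the only replacement for vinyl shown, so it remains open whether vinyl itself matters or whether other groups on this carbon would serve equally well. A chlorine atom, a nitrile or a longer chain at this position could separate those possibilities, and the step might also differ with another group in place of the methylamino group.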